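The source may report more compounds than this note shows. Statements on the series, on what has been measured and on what is new or still open speak of the compounds shown alone.

Three compounds have numbers in a functional assay with Homo sapiens as the target; on this read-out lower numbers stand for stronger inhibition and higher numbers for weaker inhibition. Compound 1 `Cc1c(C(=O)Nc2ccc(C(F)(F)F)cc2)cnn1-c1ccc(F)c(Cl)c1` gives 1300 nM and stands lowest of the three. Compound 2 `Cc1c(C(=O)N(CC(=O)O)c2ccc(C(F)(F)F)cc2)cnn1-c1ccc(F)cc1` gives 3200 nM, a higher number that lies beyond the scatter of the measurement, and compound 3 `Cc1c(C(=O)Nc2ccccc2F)cnn1-c1ccc(F)cc1` gives 4000 nM, the highest of the three, also beyond the scatter from compound 1. Compound 4 `Cc1c(C(=O)Nc2ccc(C(F)(F)F)cc2)cnn1-c1cccc(F)c1` has not been measured. The change from compound 1 to compound 4 is a single one: 3-fluorophenyl in place of 3-chloro-4-fluorophenyl on an aromatic nitrogen. The group that leaves carries one fluorine and one chlorine; the group that enters carries one fluorine only. For the measured compounds named here, no pair of measured compounds shows the effect of this exchange on its own, so the size of the step rests on expectation. The step from compound 1 to compound 4 is expected to be small, toward weaker inhibition, and likely within or only just beyond the scatter, a 1.9-fold higher number from compound 1 to compound 4 (0.28 log units; within the scatter). Compound 4 is therefore estimated at 2500 nM, with a range from 900 nM to 7000 nM.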

Compound 4, half-maximal inhibitory concentration: 3100 nM
Compound 4: middle estimate off by 1.2-fold (0.09 log units), on the low side; low and high end bracket the measured number.
By their numbers in this assay, from the lowest: compound 1; then compounds 4, 2 and 3 (each within the scatter of the next).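

In this assay, for the compounds shown here, putting 3-fluorophenyl in place of 3-chloro-4-fluorophenyl on the aromatic nitrogen gives a 2.4-fold higher number from compound 1 to compound 4 (0.38 log units; beyond the scatter) and provides the only direct reading of this position, as no earlier pair differed in one place. With the rest of the molecule unchanged, the exchange shows that the number responds to the aryl group here, and that the group with one heavy atom fewer gives the higher number. Nothing measured here explains the size or direction of this step.

The compounds shown leave open how much of the step belongs to the loss of the chlorine and how much to the different place of the fluorine, as the two groups differ in both. Also open, as far as these compounds go, is how a 3-chlorophenyl or a 3-methoxyphenyl group would read on this nitrogen.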